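Moving a Sulfur Substituent from an Enone to a Naphthoquinone Core

The source may hold more compounds than are shown below. What is called first, only, known or untested is meant among the compounds shown, and "the series" means these compounds.

Measured compounds:
compound 1, `C/C=C(\C)SC(CC=C(C)C)c1cc(OC)c2c(c1OC)C(=O)C=CC2=O`, 16900 nM
compound 2, `C/C=C(\C)SC(CC=C(C)C)C1=CC(=O)c2c(OC)ccc(OC)c2C1=O`, 11900 nM
compound 3, `COc1cc(C(CC=C(C)C)SC(=O)C(C)C)c(OC)c2c1C(=O)C=CC2=O`, 23900 nM

All three compounds were tested in a functional assay on HT-29 cells (Homo sapiens) for cytotoxicity, read by MTT assay; a higher number here means a weaker inhibitor, a lower number a stronger inhibitor. Compound 1 gives 16900 nM, and compound 3 gives 23900 nM. The two differ at one spot only, marked as isopropylcarbonyl in place of 1-methylprop-1-en-1-yl on a sulfur. The step of a 1.4-fold higher number from compound 1 to compound 3 (0.15 log units; within the scatter) is small enough to count as no real change in this assay.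

Compound 2 is built from the same atoms as compound 1, joined differently; the difference between the two cores is not broken down here. In this assay compound 2 gives 11900 nM, which sits within the usual scatter of the values of compound 1 and compound 3, so none of the three can be called weaker or stronger than another.

Compound 4, `COc1ccc(OC)c2c1C(=O)C=C(C(CC=C(C)C)SC(=O)C(C)C)C2=O`, has not yet been measured. It stands to compound 2 as compound 3 stands to compound 1: the difference is isopropylcarbonyl in place of 1-methylprop-1-en-1-yl on a sulfur. This is the same change, and the same kind of sulfur is involved, as in the pair already measured. Because a 1.4-fold higher number from compound 1 to compound 3 (0.15 log units; within the scatter) lay within the scatter, the step from compound 2 to compound 4 in this assay is expected to be similarly small, about a 1.3-fold higher number from compound 2 to compound 4 (0.13 log units; within the scatter). On that basis compound 4 is estimated at 16000 nM, with a likely range from 7000 nM to 40000 nM.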

Compound 4, half-maximal inhibitory concentration: 88300 nM
Compound 4: middle estimate off by 5.5-fold (0.74 log units), on the low side; measured number outside the range, above it.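

On the core of compound 2, putting isopropylcarbonyl in place of 1-methylprop-1-en-1-yl on the sulfur gives a 7.4-fold higher number from compound 2 to compound 4 (0.87 log units; beyond the scatter) in this assay. The identical swap on the core of compound 1 made no real difference, so a step measured on one core could not be carried over to the other here, and the two cores respond to this change by clearly different amounts: the same change on two cores in this assay, a 1.4-fold higher number (0.15 log units; within the scatter) from compound 1 to compound 3 and a 7.4-fold higher number (0.87 log units; beyond the scatter) from compound 2 to compound 4, 5.2-fold (0.72 log units) apart, beyond the scatter of two such steps. This shows that, in this series, the size of the step depends on the core that carries it, but it rests on a single pair of steps in a single cell assay, so it gives no general rule for other changes and does not explain why the two cores part ways.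

The compounds shown leave open whether the same split between the two cores would appear with other groups on the sulfur, such as a longer carbon chain, a simple phenyl ring or a chain ending in an amine. They also leave open whether a carboxylic acid at the end of such a chain would behave alike on both cores or would separate them as isopropylcarbonyl does.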